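Adding a bromo to an inactive compound

This account rests on a few compounds, and the source may have more. Where it says the series, first, only, none or still open, it means among the compounds named here.

Compound 1 `O=C(CCCCC(S)CCS)NO`: 17.7%
Compound 2 `O=C(CCCCC1CCSS1)Nc1ccc(Br)cn1`: 38%
Compound 3 `O=C(CCCCC(S)CCS)Nc1ccccn1`: "not active" (no number reported)

All three were tested in a functional assay on NCI-H460 cells (Homo sapiens) for inhibition, read by MTT assay, with a stated time of 24 h, tested at 10 ug/mL; a higher number here means more inhibition of growth at the concentration tested, a lower number less inhibition of growth. There, compound 3 has no single number and stands only as "not active" (no number reported), so it offers no exact starting point. Compound 4 `O=C(CCCCC(S)CCS)Nc1ccc(Br)cn1` makes one change to compound 3: bromo in place of hydrogen on an aromatic carbon. Among the compounds with values here, no measured pair shows this change alone, so a moderate upward step in this assay is only an expectation. It rests on compound 2, which carries the same bromo and gives 38%, though its sulfur-bearing end differs. For compound 4 the estimated value is 25%, with an expected range of 5% to 45%.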

Compound 4, percent growth inhibition at one concentration: 39.3%
Estimate against measurement, compound 4: 14.3 percentage points below; low and high end bracket the measured number.
By their numbers in this assay, from the lowest: compound 1; then compounds 2 and 4 (each within the scatter of the next).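

In this assay the bromo separates "not active" compound 3 from compound 4 at 39.3% so this ring carbon can decide whether growth inhibition shows up at all, although the size of that step cannot be read. The comparison with the ring-closed form gives a number 1.3 percentage points higher from compound 2 to compound 4 (within the scatter) and so, with the bromo present, the open sulfur-bearing chain and the five-membered ring stand level. From the compounds shown here alone, whether a chloro or a methoxy at this place would do the same remains open. Nothing measured here explains the effect of the bromo.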